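The compounds below may be only part of what the source reports. "The series", "measured", "known", "first", "only" and "open" are said of these compounds alone.

Measured in a functional assay on MCF7 cells (Homo sapiens) for antiproliferative activity, read by MTT assay, with a stated time of 48 h; a higher number here means a weaker inhibitor, a lower number a stronger inhibitor:
Compound 1 `COc1ccc(C(=O)Nc2nnc(/C=C/c3cc(OC)c(OC)c(OC)c3Br)s2)cc1`: 560 nM
Compound 2 `COc1cc(/C=C/c2nnc(NC(=O)c3ccc(Br)cc3)s2)c(Br)c(OC)c1OC`: 320 nM
Compound 3 `COc1cc(/C=C/c2nnc(NC(=O)c3cccc(Cl)c3)s2)c(Br)c(OC)c1OC`: 230 nM

Compound 3 stands clear of compound 1 but cannot be told apart from compound 2. Compound 4 `COc1cc(/C=C/c2nnc(NC(=O)c3cccc(O)c3)s2)c(Br)c(OC)c1OC` carries hydroxy in place of chloro on an aromatic carbon, meta to a large group: hydroxy in place of chloro on an aromatic carbon. Among the compounds with values here, no measured pair makes this exact swap. The nearest evidence comes from changing the phenyl group on the carbonyl: a 2.4-fold lower number from compound 1 to compound 3 (0.39 log units; beyond the scatter), and a 1.4-fold lower number from compound 2 to compound 3 (0.14 log units; within the scatter). These steps are small, so only a small step is expected in this assay, perhaps toward a higher number, as with the oxygen-bearing compound 1 at 560 nM. The expected step is a 1.5-fold higher number from compound 3 to compound 4 (0.18 log units; within the scatter). Compound 4 is estimated at 350 nM, with an expected range of 120 nM to 1000 nM.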

Compound 4, half-maximal inhibitory concentration: 360 nM
Compound 4: the middle estimate sits 1.0-fold (0.01 log units) below what was measured; measured number inside the range.
By their numbers in this assay, from the lowest: compounds 3, 2, 4 and 1 (each within the scatter of the next, the first and the last beyond it).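

In this assay, the hydrogen-bond donor and acceptor that hydroxy adds, and chloro lacks, leave no step beyond the scatter at this position (a 1.6-fold higher number from compound 3 to compound 4 (0.19 log units; within the scatter)). The 3-hydroxyphenyl group also cannot be told apart from the groups on the carbonyl carbon of the other two compounds (a 1.1-fold higher number from compound 2 to compound 4 (0.05 log units; within the scatter); a 1.6-fold lower number from compound 1 to compound 4 (0.19 log units; within the scatter)). Nothing in the available data explains these small steps. Still open, on these data alone, is whether an amine or a carboxylic acid in this place would also stay within the scatter of compound 3.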